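Replacing pyridin-2-yl on compound 1: what to expect

This account rests on a few compounds, and the source may have more. Where it says the series, first, only, none or still open, it means among the compounds named here.

Measured compounds:
- compound 1, `Cc1cccc(C(=O)NCN2CCC(c3ccccn3)CC2)c1`: 67%
- compound 2, `CSc1cccc(NC(=O)CN2CCC(c3cccc[n+]3[O-])CC2)c1`: 56%
- compound 3, `Cc1cc(F)ccc1NC(=O)CN1CCC(c2cccc[n+]2[O-])CC1`: 84%

All three numbers come from a functional assay on HEK293 cells for agonist activity at D(4) dopamine receptor (Homo sapiens), read by FLIPR; on this read-out higher numbers stand for larger maximal responses and lower numbers for smaller maximal responses. Compound 1 stands second highest of the three: compound 2 lies lower and compound 3 higher, both beyond the scatter of repeated measurements.

Compound 4, `Cc1cccc(C(=O)NCN2CCC(c3cccc[n+]3[O-])CC2)c1`, has not yet been measured. It differs from compound 1 in one place: a group of 7 heavy atoms (5 carbon, 1 nitrogen, 1 oxygen; one six-membered aromatic ring with 1 hetero atom) in place of a group of 6 heavy atoms (5 carbon, 1 nitrogen; one six-membered aromatic ring with 1 hetero atom), on a saturated ring carbon. The amide part and the rest of the shared core are unchanged.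

Among the compounds with values here, no measured pair shows this exact change. Within the data shown here, the only step available, a number 28 percentage points higher from compound 2 to compound 3 (beyond the scatter), swaps the aryl group on the amide nitrogen while both compounds already carry the entering group, so it says little about the change from compound 1 to compound 4. What compounds 2 and 3 do show is that the entering group is compatible with both a lower and a higher response than that of compound 1, so there is no basis to expect a shift beyond the scatter in this assay.

The expected step from compound 1 to compound 4 is therefore a number 3 percentage points higher from compound 1 to compound 4 (within the scatter). Compound 4 is estimated at 70%, with a range from 50% to 90%.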

Compound 4, largest response reached (reported as efficacy), in percent of the reference or control that the assay uses: 77%
The estimate for compound 4 lay 7 percentage points below the measured number, within the range that was stated.
By their numbers in this assay, from the lowest: compound 2; then compounds 1, 4 and 3 (each within the scatter of the next, the first and the last beyond it).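

In this assay, within the data shown here, the pair of compound 1 and compound 4 is the first direct test of this change. Only the group on the saturated ring carbon differs: the group of 7 heavy atoms, with its added oxygen, in place of pyridin-2-yl gives a number 10 percentage points higher from compound 1 to compound 4 (within the scatter). Compound 2 and compound 3 already carried the entering group, so they could not isolate its effect, whereas this pair shows that, with the amide part and the rest of the shared core held constant, the change produces no step beyond the scatter. The two groups have the same counts of hydrogen-bond donors and acceptors and no net charge, but no measurement given here explains the result, so it remains an observation without a known cause.

This single pair leaves open how the response would change with a different group on the same ring carbon, such as a carboxylic acid, an aminomethyl group or an unsubstituted phenyl ring. It also leaves open whether the same replacement would give a similar step with the different amide parts of compound 2 and compound 3.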